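From 3-oxomorpholin-4-yl to 1H-1,2,3-triazol-1-yl: compound 4

This account rests on a few compounds, and the source may have more. Where it says the series, first, only, none or still open, it means among the compounds named here.

Of the compounds shown here, three on the shared core have been measured in a physicochemical assay for solubility; on this read-out lower numbers stand for lower solubility and higher numbers for higher solubility. Compound 1 `O=S(=O)(Nc1nccs1)c1ccc2c(c1)OCC[C@H]2c1ccc(C(F)(F)F)cc1-n1ccnn1` gives 154000 nM, compound 2 `O=S(=O)(Nc1nccs1)c1ccc2c(c1)OCC[C@@H]2c1ccc(C(F)(F)F)cc1N1CCNCC1` gives 288000 nM, and compound 3 `O=C1COCCN1c1cc(C(F)(F)F)ccc1[C@H]1CCOc2cc(S(=O)(=O)Nc3nccs3)ccc21` gives 695000 nM. Compound 3 therefore holds the highest of the three numbers, with compound 2 nearest and compound 1 furthest.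

The change under consideration leads to compound 4 `O=S(=O)(Nc1nccs1)c1ccc2c(c1)OCC[C@@H]2c1ccc(C(F)(F)F)cc1-n1ccnn1`, with 1H-1,2,3-triazol-1-yl in place of 3-oxomorpholin-4-yl on an aromatic carbon.

Among the measured compounds shown here, only one measured step touches this position, a 2.4-fold higher number from compound 2 to compound 3 (0.38 log units; beyond the scatter). It is modest and beyond the scatter, but it exchanges piperazin-1-yl for 3-oxomorpholin-4-yl and never involves the triazole, so it sets no size for the present change. The closer guide is compound 1, which also carries 1H-1,2,3-triazol-1-yl and reads 154000 nM in this assay, well under compound 3. A fall in the number is therefore expected, close to the gap between those two values. The expected change is a 4.1-fold lower number from compound 3 to compound 4 (0.61 log units; beyond the scatter), which would lie beyond the scatter. For compound 4 the estimated value is 170000 nM, with an expected range of 90000 nM to 320000 nM.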

Compound 4, solubility: 171000 nM
Estimate against measurement, compound 4: 1.0-fold (0.00 log units) below; low and high end bracket the measured number.
By their numbers in this assay, from the lowest: compounds 1, 4 and 2 (each within the scatter of the next); then compound 3.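

In this assay the exchange of 3-oxomorpholin-4-yl for 1H-1,2,3-triazol-1-yl now has a direct reading, a 4.1-fold lower number from compound 3 to compound 4 (0.61 log units; beyond the scatter) on an aromatic carbon ortho to a large group and meta to a trifluoromethyl group. The exchange of piperazin-1-yl for the triazole gives a 1.7-fold lower number from compound 2 to compound 4 (0.23 log units; within the scatter) and cannot be told apart from repeat scatter, so among the three groups at this position only 3-oxomorpholin-4-yl stands clear of the others, with compound 3 beyond the scatter of both compound 2 and compound 4. The two triazole compounds give a 1.1-fold higher number from compound 1 to compound 4 (0.05 log units; within the scatter) and so show no readable effect of the drawn configuration at the saturated ring carbon, a comparison that isolates this one feature: the fact that compounds 1 and 4 differ only in the configuration as drawn.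

Whether the higher number of compound 3 goes with the ring carbonyl stays open, as no morpholin-4-yl group, which lacks that carbonyl, stands among the compounds shown. Also open, from the compounds shown here alone, is how a carboxylic acid would read at this position, and whether the opposite drawn configuration leaves the numbers of the piperazin-1-yl and 3-oxomorpholin-4-yl compounds as unchanged as it does for the triazole pair.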